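The source may hold more compounds than are shown below. What is called first, only, known or untested is meant among the compounds shown, and "the series" means these compounds.

Working notes on the series. Compound 1 `Cn1ccc2cc(-c3ccn4c(CC(F)(F)F)cnc4c3C#N)cc(Cl)c21` gives 120 nM in a functional assay on CHO cells for agonist activity at metabotropic glutamate receptor 2 (Homo sapiens), read by GTPgammaS binding; a higher number here means that more compound is needed for the effect, a lower number that less compound is needed. Among the three measured compounds it stands second highest: compound 3 `N#Cc1c(-c2cc(Cl)c3c(ccn3CC3CC3)c2)ccn2c(CC(F)(F)F)cnc12` gives 110 nM, and a 1.1-fold lower number from compound 1 to compound 3 (0.04 log units; within the scatter) lies within the scatter; compound 2 `N#Cc1c(-c2cc(Cl)c3[nH]ccc3c2)ccn2c(CC(F)(F)F)cnc12` gives 320 nM, and a 2.7-fold higher number from compound 1 to compound 2 (0.43 log units; beyond the scatter). The remaining measured step, a 2.9-fold lower number from compound 2 to compound 3 (0.46 log units; beyond the scatter), likewise varies the group on the aromatic nitrogen. Compound 4 `Cn1ccc2cc(-c3ccn4c(CC(F)(F)F)cnc4c3C#N)ccc21` differs from compound 1 by hydrogen in place of chloro on an aromatic carbon. For the measured compounds named here, no measured step involves the chloro; all three measured steps concern the aromatic nitrogen only, so nothing measured bears directly on the step to compound 4. For compound 4 a modest rise in the number is expected, a 2.1-fold higher number from compound 1 to compound 4 (0.32 log units; beyond the scatter), with an estimate of 250 nM in this assay and a range from 80 nM to 800 nM.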

Compound 4, half-maximal effective concentration: 230 nM
The estimate for compound 4 lay 1.1-fold (0.04 log units) above the measured number; the measured number falls inside the stated range.
By their numbers in this assay, from the lowest: compounds 3, 1, 4 and 2 (each within the scatter of the next, the first and the last beyond it).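

For the compounds shown here, this is the first measured step at the chloro position, an aromatic carbon ortho to a fused ring: with hydrogen in place of chloro, the step is a 1.9-fold higher number from compound 1 to compound 4 (0.28 log units; within the scatter) in this assay. On this pair, with methyl on the aromatic nitrogen, the chloro is therefore not shown to be needed, since the two numbers cannot be told apart. No evidence at hand gives a reason for this result.

Open, going by these compounds, is how a fluoro, methyl or methoxy group on this carbon would read. Also open, on these data alone, is whether the same exchange gives a comparable step when the aromatic nitrogen carries hydrogen or cyclopropylmethyl.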